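A few compounds are considered here, and "the series" means these few. Any claim that something is new, unique, unknown or untested is made for them only; others in the source may bear on it.

Measured in a functional assay on COLO 205 cells (Homo sapiens) for inhibition, read by sulforhodamine B assay, with a stated time of 48 h, tested at 10 uM; on this read-out lower numbers stand for less inhibition of growth and higher numbers for more inhibition of growth at the one concentration tested:
Compound 1 `COc1ccc(-c2nc3sc(-c4ccccc4)cn3n2)cc1`: 63%
Compound 2 `Clc1ccc(-c2cn3nc(-c4ccccc4)nc3s2)cc1`: 18%
Compound 3 `COc1ccc(-c2nc3sc(-c4ccc(Cl)cc4)cn3n2)cc1`: 47.5%

Compound 2 has the lowest number of the three, and its gaps to the other two lie beyond the usual scatter. Compound 4 `c1ccc(-c2nc3sc(-c4ccccc4)cn3n2)cc1` has not yet been measured. Its structure departs from compound 2 as follows: hydrogen in place of chloro on an aromatic carbon. In short, this is hydrogen in place of chloro on an aromatic carbon.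

The closest evidence is the opposite change, chloro in place of hydrogen, made on another pair of compounds. That gave a number 15.5 percentage points lower from compound 1 to compound 3 (beyond the scatter), a modest step beyond the scatter. Read in reverse, it suggests that losing the chloro should raise the number by a similar amount. The methoxy step, a number 29.5 percentage points higher from compound 2 to compound 3 (beyond the scatter), is a change at a different place, so it bears on this question only loosely. With a single pair as a guide, the expectation stays rough.

The expected change is a number 17 percentage points higher from compound 2 to compound 4 (beyond the scatter), a modest rise. For compound 4 the estimated value is 35%, with an expected range of 18% to 52%.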

Compound 4, percent growth inhibition at one concentration: 5%
Beside the measured number, compound 4's estimate is 30 percentage points above it, outside the stated range (below it).
By their numbers in this assay, from the lowest: compound 4; then compound 2; then compound 3; then compound 1.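

Going from 4-chlorophenyl to phenyl gives a number 13 percentage points lower from compound 2 to compound 4 (beyond the scatter), so this step runs the opposite way to the same change on the pair carrying the methoxy group. The chloro therefore has no single effect at this position, and the direction of its step depends on what the rest of the molecule carries: the same change on two cores in this assay, a number 15.5 percentage points lower (beyond the scatter) from compound 1 to compound 3 and a number 13 percentage points higher (beyond the scatter) from compound 4 to compound 2, 28.5 percentage points apart, beyond the scatter of two such steps Losing the methoxy also costs more in the compounds without the chloro, with a number 58 percentage points lower from compound 1 to compound 4 (beyond the scatter), than in those with it: the same change on two cores in this assay, a number 29.5 percentage points higher (beyond the scatter) from compound 2 to compound 3 and a number 58 percentage points higher (beyond the scatter) from compound 4 to compound 1, 28.5 percentage points apart, beyond the scatter of two such steps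

As far as these compounds go, only hydrogen, chloro and methoxy appear here, so it stays open whether a fluoro, a hydroxyl or an amine at this position would follow the chloro. From the compounds shown here alone, with one pair per core, it also stays open whether this dependence holds for any other group.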